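A methyl group on the core of compound 1

The source may hold more compounds than are shown below. What is called first, only, known or untested is meant among the compounds shown, and "the series" means these compounds.

For the measured compounds named here, in a functional assay on DLD-1 cells (Homo sapiens) for cytotoxicity, with a stated time of 48 h (on this read-out lower numbers stand for stronger inhibition and higher numbers for weaker inhibition), compound 1 (`C[S+]([O-])/C=C/c1cc(=O)c2ccccc2o1`) gives 8000 nM and stands within the scatter of the only other measured compound. That is compound 2 (`CC(C)CC(=O)Oc1ccc2oc(/C=C/[S+](C)[O-])cc(=O)c2c1`), which gives 6100 nM as its value. Compound 3 (`Cc1c(/C=C/[S+](C)[O-])oc2ccccc2c1=O`) has methyl in place of hydrogen on an aromatic carbon of the core of compound 1, a change counted as methyl in place of hydrogen on an aromatic carbon here. Going by the values given here, one measured step bears on it only indirectly: a 1.3-fold lower number from compound 1 to compound 2 (0.12 log units; within the scatter) is the sole change on this core, and it brings in (isobutylcarbonyl)oxy rather than methyl. With so little to go on, no step beyond the scatter is expected in this assay and no direction can be favoured. The expected change is a 1.1-fold lower number from compound 1 to compound 3 (0.06 log units; within the scatter) on this estimate. For compound 3 the estimated value is 7000 nM, with an expected range from 2500 nM to 18000 nM for the measurement.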

Compound 3, half-maximal inhibitory concentration: 7200 nM
For compound 3 the middle estimate is 1.0-fold (0.01 log units) below the measured one; the measured number falls inside the stated range.
By their numbers in this assay, from the lowest: compounds 2, 3 and 1 (each within the scatter of the next).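

In this assay the step with methyl in place of hydrogen on an aromatic carbon is a 1.1-fold lower number from compound 1 to compound 3 (0.05 log units; within the scatter) and so cannot be told apart from repeat measurements, which shows that this carbon, two atoms from the ring oxygen, carries a methyl group with no readable change in cytotoxicity. For the compounds shown here, the earlier step brought in (isobutylcarbonyl)oxy at a different place on the core, so this is the only reading here from the six-membered aromatic ring with 1 oxygen. No measurement at hand gives a reason for this result.

As far as these compounds go, whether a longer chain, an amine or a carboxylic acid on this same carbon would move the number beyond the scatter remains open. Also open, from the compounds shown here alone, is whether methyl here would behave the same with (isobutylcarbonyl)oxy present on the core.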